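This account rests on a few compounds, and the source may have more. Where it says the series, first, only, none or still open, it means among the compounds named here.

Measured compounds:

compound 1, `COc1ccc(C2N=C(SCc3ccccc3)NC(C)=C2C(=O)Nc2ccc(F)cc2)cc1OC`, gives 1%
compound 2, `COc1ccc(C2N=C(SCc3cccc(Cl)c3)NC(C)=C2C(=O)Nc2ccc(F)cc2)cc1OC`, gives 13.3%
compound 3, `COc1ccc(C2N=C(SCc3ccccc3)NC(C)=C2C(=O)Nc2ccc(Br)cc2)cc1`, gives 5.6%

All three were tested in a functional assay on the whole organism (artery, strain albino) with Rattus norvegicus as the target, with a stated time of 900 min, at a dose of 10 mg/kg by the oral route; on this read-out higher numbers stand for more inhibition at the one dose given (going by the name of the read-out) and lower numbers for less inhibition. Compound 2 differs from compound 1 by chloro in place of hydrogen on an aromatic carbon, and this gave a number 12.3 percentage points higher from compound 1 to compound 2 (beyond the scatter). Compound 3 carries a different core; how it differs from compound 1 is not broken down here. Its value lies within the scatter of both compound 1 and compound 2, so no order among them can be read from these three numbers.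

Compound 4, `COc1ccc(C2N=C(SCc3ccccc3Cl)NC(C)=C2C(=O)Nc2ccc(Br)cc2)cc1`, is not yet measured. It differs from compound 3 by chloro in place of hydrogen on an aromatic carbon. Among the measured compounds shown here, this is the same kind of change as the one from compound 1 to compound 2, but not the same: there the chlorine sits meta to a large group, here it sits ortho to a large group. Resting on a number 12.3 percentage points higher from compound 1 to compound 2 (beyond the scatter), a rise of similar order is expected, though the other position and the other core leave it uncertain; the step expected is a number 7.4 percentage points higher from compound 3 to compound 4 (within the scatter). Compound 4 is therefore estimated at 13%, most likely between 0% and 30%.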

Compound 4, a percentage reported as inhibition, in the whole organism at one dose (the size of the read-out at that dose, not a potency): 7.2%
The estimate for compound 4 lay 5.8 percentage points above the measured number; the measured number falls inside the stated range.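

In this assay, chloro in place of hydrogen gave a number 1.6 percentage points higher from compound 3 to compound 4 (within the scatter), so this step alone cannot be told apart from the ordinary spread of repeated measurements. Set beside the earlier step, it does not differ clearly from it: the same change on two cores in this assay, a number 12.3 percentage points higher (beyond the scatter) from compound 1 to compound 2 and a number 1.6 percentage points higher (within the scatter) from compound 3 to compound 4, 10.7 percentage points apart, within the scatter of two such steps. This shows no firm effect of the core on the change, but it does not show that the change carries over either: only the earlier step lies beyond the scatter, and the two steps differ in the place of the chlorine on the ring as well as in the core, so these two differences cannot be separated here.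

Still open, on these data alone, is what 2-chlorobenzyl would give on the core of compound 1, a comparison that would hold the core fixed and vary only the place of the chlorine. Also open, as far as these compounds go, is how a nitrile or an amine on the benzyl ring, rather than chloro, would read out in this assay.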